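Moving the methoxy group: compound 2 to compound 3

The source may hold more compounds than are shown below. What is called first, only, known or untested is meant among the compounds shown, and "the series" means these compounds.

Of the compounds shown here, two have so far been measured in a functional assay on A549 cells (Homo sapiens) for antiproliferative activity, read by MTT assay, with a stated time of 48 h; on this read-out higher numbers stand for weaker inhibition and lower numbers for stronger inhibition. Compound 1 `O=C(/C=C/c1ccccc1)Nc1ccc2ncnc(Nc3cccc(Br)c3)c2c1` gives 3.96 ug/mL, and compound 2 `COc1ccc(/C=C/C(=O)Nc2ccc3ncnc(Nc4cccc(Br)c4)c3c2)cc1` gives 3.36 ug/mL, so the two sit within the scatter of each other, as the step of a 1.2-fold lower number from compound 1 to compound 2 (0.07 log units; within the scatter) shows. Compound 3 `COc1ccccc1/C=C/C(=O)Nc1ccc2ncnc(Nc3cccc(Br)c3)c2c1` differs from compound 2 by 2-methoxyphenyl in place of 4-methoxyphenyl on a double-bonded chain carbon bound to a double-bonded chain carbon. Going by the values given here, no measured step moves the methoxy group from one position to another, and the only known step, which adds that group, stayed within the scatter. Therefore no change beyond the scatter is expected in this assay. The estimate for compound 3 is 3.5 ug/mL, with a range from 1.7 ug/mL to 7.2 ug/mL, a step of a 1.0-fold higher number from compound 2 to compound 3 (0.02 log units; within the scatter).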

Compound 3, half-maximal inhibitory concentration: 3.55 ug/mL
The estimate for compound 3 lay 1.0-fold (0.01 log units) below the measured number; measured number inside the range.
By their numbers in this assay, from the lowest: compounds 2, 3 and 1 (each within the scatter of the next).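

Swapping 4-methoxyphenyl for 2-methoxyphenyl gives a 1.1-fold higher number from compound 2 to compound 3 (0.02 log units; within the scatter) in this assay and so adds a change of the group's place to what was known. Set against the ring with no methoxy group, the new placement gives a 1.1-fold lower number from compound 1 to compound 3 (0.05 log units; within the scatter) and so, like the earlier placement, does not separate from it. No available measurement offers an explanation for this flat result.

As far as these compounds go, whether an amine or a carboxylic acid in place of the methoxy group would move the number beyond the scatter stays open.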